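Swapping Bromo for Methoxy on a Bicyclic Urea

A few compounds are considered here, and "the series" means these few. Any claim that something is new, unique, unknown or untested is made for them only; others in the source may bear on it.

Compound 1 `O=C(Nc1cccc2[nH]ncc12)NC1CCc2cc(Br)ccc21` gives 9 nM in an assay on isolated protein for inhibition of transient receptor potential cation channel subfamily V member 1 (Homo sapiens), read by calcium flux; a higher number here means a weaker inhibitor, a lower number a stronger inhibitor.
Compound 2 `O=C(Nc1cccc2[nH]ncc12)NC1CCOc2cc(C(F)(F)F)ccc21` gives 11 nM in this assay.

Compound 1 has the lowest of these two numbers, yet compound 2 sits within the scatter of it, so the two cannot be ordered. Compound 3 `COc1ccc2c(c1)CCC2NC(=O)Nc1cccc2[nH]ncc12` differs from compound 1 by methoxy in place of bromo on an aromatic carbon. Among the compounds with values here, no measured pair shows this change, so nothing here sets its size. The step of a 4.4-fold higher number from compound 1 to compound 3 (0.65 log units; beyond the scatter) is expected to go toward a higher number, beyond the scatter. Compound 3 is therefore estimated at 40 nM, with a range from 10 nM to 160 nM.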

Compound 3, half-maximal inhibitory concentration: 40 nM
Compound 3: middle estimate and measured number agree at the digits printed; the range from low to high includes it.
By their numbers in this assay, from the lowest: compounds 1 and 2 (each within the scatter of the next); then compound 3.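

In this assay, methoxy in place of bromo on this aromatic carbon gives a 4.4-fold higher number from compound 1 to compound 3 (0.65 log units; beyond the scatter) and so marks a weaker inhibitor. This position is therefore not indifferent to the group it carries, which the first two compounds could not show. Nothing measured here accounts for the size of this step.

On these data alone, whether chloro, fluoro or the longer ethoxy would keep the number close to that of compound 1 remains open. So does whether the same swap would have a similar effect on another core.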